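Fluoro on the Fused Ring of a Benzimidazole Amylase Inhibitor

The source may report more compounds than this note shows. Statements on the series, on what has been measured and on what is new or still open speak of the compounds shown alone.

Measured compounds:
compound 1 `COc1cccc(-c2nc3ccccc3[nH]2)c1Cl`: 2740 nM
compound 2 `COc1cc(-c2nc3cc(C)c(C)cc3[nH]2)cc(I)c1O`: 1770 nM

For the measured compounds named here, in an assay for inhibition of Alpha amylase (Homo sapiens), with a stated time of 10 min (on this read-out lower numbers stand for stronger inhibition and higher numbers for weaker inhibition), compound 1 gives 2740 nM, one of only two numbers available. Compound 2 gives 1770 nM, and the two values lie within the usual scatter of each other, so neither compound is distinguished from the other. Compound 3 `COc1cccc(-c2nc3cc(F)ccc3[nH]2)c1Cl` is not yet measured; it differs from compound 1 by fluoro in place of hydrogen on an aromatic carbon. Going by the values given here, no measured pair shows this change, so the step expected for a 1.1-fold lower number from compound 1 to compound 3 (0.04 log units; within the scatter) is small, in no particular direction, and not beyond the scatter. Compound 3 is therefore estimated at 2500 nM, with a range from 1000 nM to 6500 nM.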

Compound 3, half-maximal inhibitory concentration: 2620 nM
Compound 3: middle estimate off by 1.0-fold (0.02 log units), on the low side; the range from low to high includes it.
By their numbers in this assay, from the lowest: compounds 2, 3 and 1 (each within the scatter of the next).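

In this assay, fluoro in place of hydrogen on an aromatic carbon of the six-membered ring of carbon only gives a 1.0-fold lower number from compound 1 to compound 3 (0.02 log units; within the scatter), so this position takes that single fluorine without leaving the scatter. For the compounds shown here, this is the first pair here that differs in one place, which lets a single change at this position be read directly. Nothing measured here speaks to what lies behind this result.

From the compounds shown here alone, whether an amine or a carboxylic acid in the same place would give a step beyond the scatter stays open. So does the outcome of fluoro on the other carbons of that ring.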